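The source may hold more compounds than are shown below. What is called first, only, known or untested is meant among the compounds shown, and "the series" means these compounds.

Measured in a functional assay on LNCaP cells (Homo sapiens) for antiproliferative activity, read by propidium iodide staining, with a stated time of 96 h; on this read-out higher numbers stand for weaker inhibition and lower numbers for stronger inhibition:
- compound 1 `CC(O)(CSc1ccc(S(F)(F)(F)(F)F)cc1)C(=O)Nc1ccc(S(F)(F)(F)(F)F)cc1`: 18300 nM
- compound 2 `CC(O)(CSc1ccc(F)cc1)C(=O)Nc1ccc(S(F)(F)(F)(F)F)cc1`: 12500 nM
- compound 3 `CC(O)(CSc1ccc(C(F)(F)F)cc1)C(=O)Nc1ccc(S(F)(F)(F)(F)F)cc1`: 17000 nM

Compound 3 sits within the scatter of the other two numbers. The steps are a 1.1-fold lower number from compound 1 to compound 3 (0.03 log units; within the scatter), a 1.4-fold higher number from compound 2 to compound 3 (0.13 log units; within the scatter) and a 1.5-fold lower number from compound 1 to compound 2 (0.17 log units; within the scatter).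

Compound 4 `CC(O)(CSc1ccc(OC(F)(F)F)cc1)C(=O)Nc1ccc(S(F)(F)(F)(F)F)cc1` differs from compound 3 by trifluoromethoxy in place of trifluoromethyl on an aromatic carbon. This exact change has not been measured, but all three steps above alter the same place, and none leaves the scatter. A step beyond the scatter in this assay is therefore not expected, in either direction. The expected 1.1-fold lower number from compound 3 to compound 4 (0.05 log units; within the scatter) stays small. Compound 4 is estimated at 15000 nM, with an expected range of 8000 nM to 28000 nM.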

Compound 4, half-maximal inhibitory concentration: 16100 nM
The estimate for compound 4 lay 1.1-fold (0.03 log units) below the measured number; measured number inside the range.
By their numbers in this assay, from the lowest: compounds 2, 4, 3 and 1 (each within the scatter of the next).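

In this assay, trifluoromethoxy on this aromatic carbon, para to a large group, gives a number no different from those of the three groups before it, with every step within the scatter (a 1.1-fold lower number from compound 3 to compound 4 (0.02 log units; within the scatter)) (a 1.3-fold higher number from compound 2 to compound 4 (0.11 log units; within the scatter)) (a 1.1-fold lower number from compound 1 to compound 4 (0.06 log units; within the scatter)). The change to trifluoromethoxy also brings in an oxygen and one hydrogen-bond acceptor by count, and even so the number stays within the scatter of the other three. Nothing available explains why this position shows so little response.

Going by these compounds, whether an amine or a carboxylic acid here would move the number beyond the scatter remains open. So does whether a hydroxyl or a longer chain at this position would do so.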